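A Methyl on the Aromatic Nitrogen of Compound 2

The compounds below may be only part of what the source reports. "The series", "measured", "known", "first", "only" and "open" are said of these compounds alone.

Compound 1 `COc1cc(-c2cc3nccc(-c4c[nH]c5ccccc45)n3n2)cc(OC)c1OC` and compound 2 `COc1cc(-c2ccnc3cc(-c4c[nH]c5ccccc45)nn23)cc(OC)c1OC` carry the same groups on a shared core, joined in a different pattern. In a functional assay on HCT-116 cells (Homo sapiens) for inhibition, read by CCK-8 assay, with a stated time of 48 h (a lower number here means a stronger inhibitor, a higher number a weaker inhibitor), compound 1 gives > 10000 nM, which is a limit of the assay rather than a number; this is the limit of > 10000 nM in this assay, at which 1 of the 2 values shown sits. In this assay, within the data shown here, compound 2 gives 35 nM, the only full number measured so far. Compound 3 `COc1cc(-c2ccnc3cc(-c4cn(C)c5ccccc45)nn23)cc(OC)c1OC` differs from compound 2 by methyl in place of hydrogen on an aromatic nitrogen. Compound 3 is expected to lose some potency, with an estimated step of a 3.4-fold higher number from compound 2 to compound 3 (0.54 log units; beyond the scatter). The estimate for compound 3 is 120 nM, within 30 nM to 600 nM.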

Compound 3, half-maximal inhibitory concentration: 762 nM
Compound 3: middle estimate off by 6.4-fold (0.80 log units), on the low side; measured number above the stated range.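

In this assay methyl in place of hydrogen on the aromatic nitrogen gives a 22-fold higher number from compound 2 to compound 3 (1.34 log units; beyond the scatter) and so marks this position as sensitive to a single added carbon. The hydrogen on this nitrogen of the 1H-indol-3-yl group is therefore not a free place for substitution, although compound 3 still gives a full number and not a limit. Nothing measured here accounts for the loss.

As far as these compounds go, it remains open whether the loss comes from removing the hydrogen or from adding the carbon. From the compounds shown here alone, how an ethyl, an acetyl or a 2-aminoethyl chain on this nitrogen would compare also remains open.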